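A few compounds are considered here, and "the series" means these few. Any claim that something is new, unique, unknown or untested is made for them only; others in the source may bear on it.

In a physicochemical assay for solubility, in phosphate buffer, measured as kinetic solubility, at pH 7.4, tested at 250 uM (on this read-out lower numbers stand for lower solubility and higher numbers for higher solubility), the measured compounds read:
- compound 1 `CCCCCCNc1ccc([N+](=O)[O-])cc1S(=O)(=O)N(C)C` with 1000 nM
- compound 2 `CCCCCCNc1ccc(C(=O)O)cc1S(N)(=O)=O` with 238000 nM
- compound 3 `CCCCCCNc1ccc(C(=O)O)cc1S(=O)(=O)N(C)C` with 243000 nM

Compound 3 stands level with compound 2, since the step of a 1.0-fold higher number from compound 2 to compound 3 (0.01 log units; within the scatter) lies within the scatter. Both stand far from compound 1, and the step of a 240-fold higher number from compound 1 to compound 3 (2.39 log units; beyond the scatter) lies beyond it. Compound 4 `CN(C)S(=O)(=O)c1cc(C(=O)O)ccc1NCCCCCC(F)(F)F` differs from compound 3 by a single change at the end of the chain: trifluoromethyl in place of methyl on a saturated chain carbon, five bonds along the chain from a nitrogen on an aromatic ring. The same difference can be read as butyl to 4,4,4-trifluorobutyl.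

Neither measured step touches this chain. The large one exchanges nitro for carboxy, and compound 4 keeps the carboxy group of compound 3. The other exchanges amino for dimethylamino on a sulfonyl sulfur, and compound 4 keeps the dimethylamino group too. For the measured compounds named here, the data therefore hold no direct precedent for the change, and nothing in them points to a step of the size seen from nitro to carboxy. A small move towards lower numbers is the most that is expected in this assay. The estimated step is a 1.4-fold lower number from compound 3 to compound 4 (0.13 log units; within the scatter) and would stay within the scatter. Compound 4 is expected at 180000 nM with an estimated range from 80000 nM to 260000 nM as its upper end.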

Compound 4, solubility: 249000 nM
Beside the measured number, compound 4's estimate is 1.4-fold (0.14 log units) below it; the measured number falls inside the stated range.
By their numbers in this assay, from the lowest: compound 1; then compounds 2, 3 and 4 (each within the scatter of the next).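

The earlier steps shown here changed only the nitro or carboxy group and the group on the sulfonyl sulfur, so the chain end had not yet been read. With carboxy and dimethylamino held constant, trifluoromethyl in place of methyl on a saturated chain carbon, five bonds along the chain from a nitrogen on an aromatic ring, gives a 1.0-fold higher number from compound 3 to compound 4 (0.01 log units; within the scatter) in this assay, so compound 3 and compound 4 stand level and this change leaves the read-out unmoved on this core. However, compound 4 at 249000 nM lies close to the tested concentration, as do the two other carboxy compounds, so this flat step cannot show how far the numbers might have moved without that top concentration, and nothing measured here offers an explanation for the result.

On these data alone, it remains open whether a longer chain, or a chain ending in a hydroxy group or an amine, would read differently at this place. As far as these compounds go, it is also open whether the same exchange would stay as flat on a core carrying nitro, such as that of compound 1 at 1000 nM, whose number lies well clear of the tested concentration.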